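Thiophene for Furan on the Core: Expected Receptor Inhibition

A few compounds are considered here, and "the series" means these few. Any claim that something is new, unique, unknown or untested is made for them only; others in the source may bear on it.

Measured so far:
Compound 1, `CC1=C(C(=O)OC(C)C(F)(F)F)C(c2cccs2)NC(=O)N1`: 12%; 16% (2 entries)
Compound 2, `CC1=C(C(=O)OCC(F)(F)F)C(c2ccoc2)NC(=O)N1`: 13%

Two compounds of this series have numbers in an assay on cells for displacement of a labelled ligand from adenosine receptor A1 (Homo sapiens), read by radioligand binding, with a stated time of 60 min, tested at 1 uM; on this read-out lower numbers stand for less inhibition and higher numbers for more inhibition at the one concentration tested (going by the name of the read-out). Compound 1, `CC1=C(C(=O)OC(C)C(F)(F)F)C(c2cccs2)NC(=O)N1`, has been run more than once, and the several entries of compound 1 in this assay, 12%; 16% (2 entries) shows how closely its repeats agree. Within the data shown here, compound 2, `CC1=C(C(=O)OCC(F)(F)F)C(c2ccoc2)NC(=O)N1`, gives 13% in this assay, the only number it has there; a further entry for it exists without a single number. Among the measured compounds shown here, compound 1 and compound 2 differ from each other in two places at once, so no single step is drawn between them; all that can be said is that both sit at a low level of inhibition.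

Compound 3, `CC1=C(C(=O)OCC(F)(F)F)C(c2cccs2)NC(=O)N1`, is not yet measured. It is reached from compound 2 by one change: thiophen-2-yl in place of furan-3-yl on a saturated ring carbon. For the measured compounds named here, no measured pair shows the effect of this change alone, so the expectation rests on the low level shared by compound 1 and compound 2. The step from compound 2 to compound 3 in this assay is expected to be a number 1 percentage points higher from compound 2 to compound 3 (within the scatter), that is, none beyond the usual scatter. Compound 3 is therefore estimated at 14%, with a range from 4% to 26%.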

Compound 3, a percentage reported as inhibition, at one concentration (the size of the read-out at that concentration, not a potency): 3%
The estimate for compound 3 lay 11 percentage points above the measured number, outside the stated range (below it).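

In this assay, among these compounds, compound 2 and compound 3 form the first pair that differs in one place only, so thiophen-2-yl in place of furan-3-yl on a saturated ring carbon can now be read on its own: the change gives a number 10 percentage points lower from compound 2 to compound 3 (within the scatter). Both groups are five-membered aromatic rings with 1 hetero atom, and at this position the exchange of one for the other produces no step beyond the usual scatter, with both compounds at a low level of inhibition at the one concentration tested. Repeats of a single compound give a feel for how far such numbers can drift: the several entries of compound 1 in this assay, 12%; 16% (2 entries)

The change alters both the hetero atom and the point of attachment, and this one pair cannot separate the two; furan-2-yl or thiophen-3-yl on the same carbon would be needed for that. The compounds shown also leave open what a group of another kind would do at this position, such as a phenyl ring, an amine or a carboxylic acid.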